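Two Level Values and One Unmeasured Chain Change

A few compounds are considered here, and "the series" means these few. Any claim that something is new, unique, unknown or untested is made for them only; others in the source may bear on it.

In a functional assay on MCF7 cells (Homo sapiens) for inhibition, read by MTT assay, with a stated time of 72 h (on this read-out higher numbers stand for weaker inhibition and lower numbers for stronger inhibition), compound 1 `COc1cc(NC(C)CCCCCCNC(=O)CCC(=O)NO)c2ncccc2c1` gives 1600 nM and compound 2 `COc1cc(NC(C)CCCNC(=O)CCC(=O)NO)c2ncccc2c1` gives 1600 nM as well, so compound 1 stands level with compound 2 within the scatter. Compound 3 `COc1cc(NC(C)CCCCCNC(=O)CCC(=O)NO)c2ncccc2c1` has not yet been measured. In passing from compound 1 to compound 3, ((2-(hydroxycarbamoyl)ethyl)carbonyl)amino takes the place of (((2-(hydroxycarbamoyl)ethyl)carbonyl)amino)methyl on a saturated chain carbon, six bonds along the chain from a nitrogen on an aromatic ring ((2-(hydroxycarbamoyl)ethyl)carbonyl)amino in place of (((2-(hydroxycarbamoyl)ethyl)carbonyl)amino)methyl on a saturated chain carbon, six bonds along the chain from a nitrogen on an aromatic ring and the rest of the structure stays the same. Among the compounds with values here, no measured step is available for comparison, so the expectation rests only on compound 1 at 1600 nM and compound 2 at 1600 nM being level. No step beyond the scatter is expected in this assay in either direction. The expected step is a 1.1-fold lower number from compound 1 to compound 3 (0.03 log units; within the scatter) and stays within the scatter. In this assay compound 3 is estimated at 1500 nM with an expected range from 700 nM to 3200 nM for the coming measurement.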

Compound 3, half-maximal inhibitory concentration: 1600 nM
Estimate against measurement, compound 3: 1.1-fold (0.03 log units) below; the range from low to high includes it.
By their numbers in this assay, from the lowest: compounds 1, 2 and 3 (each within the scatter of the next).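

In this assay, ((2-(hydroxycarbamoyl)ethyl)carbonyl)amino in place of (((2-(hydroxycarbamoyl)ethyl)carbonyl)amino)methyl on a saturated chain carbon, six bonds along the chain from a nitrogen on an aromatic ring, gives no change at the digits printed from compound 1 to compound 3 (within the scatter) as the first step read directly at this place. Within the data shown here, the earlier compounds offered only two level values with no step between them, whereas this single change can now be read on its own, and the number holds. No supporting data bear on why the read-out stays level at this place.

Still open, going by these compounds, is whether a longer chain, or an amine or a carboxylic acid on this chain, would also leave the number in this assay level. Also open, on these data alone, is whether a carboxylic acid in place of the hydroxycarbamoyl group would do the same.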